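This account rests on a few compounds, and the source may have more. Where it says the series, first, only, none or still open, it means among the compounds named here.

In a functional assay on HeLa cells (Homo sapiens) for cytotoxicity, read by sulforhodamine B assay, with a stated time of 48 h (a lower number here means a stronger inhibitor, a higher number a weaker inhibitor), three compounds have been measured:

compound 1 `CC1=C(/C=C/C(=O)/C=C/c2ccccc2)C(C)(C)CCC1` gives 70200 nM;
compound 2 `CC1=C(/C=C/C(=O)/C=C/c2ccc(Br)cc2)C(C)(C)CCC1` gives 88800 nM;
compound 3 `CC1=C(/C=C/C(=O)/C=C/c2ccc(C#N)cc2)C(C)(C)CCC1` gives 22200 nM.

Compound 3 stands lowest of the three, set apart by the steps of a 3.2-fold lower number from compound 1 to compound 3 (0.50 log units; beyond the scatter) and a 4.0-fold lower number from compound 2 to compound 3 (0.60 log units; beyond the scatter), while the step of a 1.3-fold higher number from compound 1 to compound 2 (0.10 log units; within the scatter) keeps compounds 1 and 2 together. Compound 4 `CC1=C(/C=C/C(=O)/C=C/c2ccc(C)cc2)C(C)(C)CCC1` differs from compound 3 by methyl in place of cyano on an aromatic carbon. Among the measured compounds shown here, no measured step introduces a methyl, so the only guidance is that the cyano group gave the two beyond-scatter steps noted above; removing it is expected to undo most of that gain and return the number toward compounds 1 and 2. Compound 4 is therefore estimated at 60000 nM, within 25000 nM to 150000 nM, an expected step of a 2.7-fold higher number from compound 3 to compound 4 (0.43 log units; beyond the scatter).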

Compound 4, half-maximal inhibitory concentration: 20400 nM
Compound 4: the middle estimate sits 2.9-fold (0.47 log units) above what was measured, outside the stated range (below it).
By their numbers in this assay, from the lowest: compounds 4 and 3 (each within the scatter of the next); then compounds 1 and 2 (each within the scatter of the next).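

In this assay, methyl on this aromatic carbon, para to a large group, stands level with cyano (a 1.1-fold lower number from compound 3 to compound 4 (0.04 log units; within the scatter)) and keeps the advantage over hydrogen (a 3.4-fold lower number from compound 1 to compound 4 (0.54 log units; beyond the scatter)) and over bromo (a 4.4-fold lower number from compound 2 to compound 4 (0.64 log units; beyond the scatter)). The lower number of compound 3 therefore does not belong to cyano alone, since methyl has no triple bond and no hydrogen-bond acceptor, while bromo in compound 2 goes against any simple pattern. Nothing measured here explains this result. Going by these compounds, whether an amine, a methoxy group or a carboxylic acid at this place would join compound 3 and compound 4 or stay with compound 1 remains open.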